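Benzyloxy for hydroxy on a pyrazolyl chalcone core

This account rests on a few compounds, and the source may have more. Where it says the series, first, only, none or still open, it means among the compounds named here.

Of the compounds shown here, three share a chalcone-type core and have been tested in a functional assay on PC-3 cells (Homo sapiens) for antiproliferative activity, read by MTT assay, with a stated time of 48 h; a higher number here means a weaker inhibitor, a lower number a stronger inhibitor. Compound 1 `CC1(C)Cc2c(O)ccc(C(=O)/C=C/c3cn(-c4ccccc4)nc3-c3cccc([N+](=O)[O-])c3)c2O1` gives 25600 nM in this assay. Compound 2 `COc1ccc(-c2nn(-c3ccccc3)cc2/C=C/C(=O)c2ccc(O)c3c2OC(C)(C)C3)cc1` gives 20800 nM in this assay, and compound 3 `COc1ccc(/C=C/C(=O)c2ccc(OCc3ccccc3)c3c2OC(C)(C)C3)cc1` gives 13500 nM in this assay. Compound 1 holds the highest of the three numbers, yet its gap to compound 2 and its gap to compound 3 both lie within the scatter, so no order among them can be read. Among the measured compounds shown here, the single measured step, a 1.2-fold lower number from compound 1 to compound 2 (0.09 log units; within the scatter), changes a distant aromatic group and stays within the scatter.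

Compound 4 `CC1(C)Cc2c(OCc3ccccc3)ccc(C(=O)/C=C/c3cn(-c4ccccc4)nc3-c3cccc([N+](=O)[O-])c3)c2O1` differs from compound 1 by benzyl in place of hydrogen on an oxygen on an aromatic ring. For the measured compounds named here, no measured pair isolates this change: compound 2 and compound 3 differ in the same place but also elsewhere, so their values cannot be assigned to the benzyl alone. With only steps within the scatter in hand, compound 4 is expected to show no step beyond the scatter, a 1.3-fold lower number from compound 1 to compound 4 (0.11 log units; within the scatter). Compound 4 is therefore estimated at 20000 nM, within 7000 nM to 60000 nM.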

Compound 4, half-maximal inhibitory concentration: 5900 nM
The estimate for compound 4 lay 3.4-fold (0.53 log units) above the measured number, outside the stated range (below it).
By their numbers in this assay, from the lowest: compound 4; then compounds 3, 2 and 1 (each within the scatter of the next).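

In this assay, benzyl in place of hydrogen on the oxygen gives a 4.3-fold lower number from compound 1 to compound 4 (0.64 log units; beyond the scatter), a modest step but the first in this set to lie beyond the scatter. Among the compounds shown here, this shows that the number responds to a change at this oxygen on the aromatic ring, which the earlier compounds could not show: their only measured step, at a distant aromatic group, stayed within the scatter. Nothing given here accounts for the size of this step.

The compounds shown leave open whether the step depends on the benzyl ring itself or would follow from any replacement of the hydroxy hydrogen, a question that a longer alkyl chain or a benzyl ring carrying a carboxylic acid on this oxygen would address. They also leave open whether the same change would give a similar step with the 4-methoxyphenyl group of compound 2 in place of 3-nitrophenyl.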